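Hydroxy to hydrogen on the side chain of compound 1

The compounds below may be only part of what the source reports. "The series", "measured", "known", "first", "only" and "open" are said of these compounds alone.

Measured compounds:
compound 1 `O=C(O)c1csc([C@H]2CC[C@@H]3[C@@H](/C=C/[C@@H](O)COc4ccccc4)[C@H](O)C[C@@H]3O2)n1` — 1.4 nM
compound 2 `O=C(O)c1csc([C@H]2CC[C@@H]3[C@@H](CCCOc4ccccc4)[C@H](O)C[C@@H]3O2)n1` — 4200 nM
compound 3 `O=C(O)c1csc([C@H]2CC[C@@H]3[C@@H](COc4ccccc4)[C@H](O)C[C@@H]3O2)n1` — limit, > 10000 nM

In a functional assay on CHO cells for agonist activity at prostaglandin E2 receptor EP1 subtype (Homo sapiens), read by fluorescence and calcium flux (a higher number here means that more compound is needed for the effect, a lower number that less compound is needed), compound 1 gives 1.4 nM, the lowest of the two numbers shown. Its nearest neighbour is compound 2, which gives 4200 nM. For compound 3 the assay reports no number but a limit, > 10000 nM. Compound 3 thus sits at the limit of > 10000 nM in this assay, at which 1 of the 3 values shown sits.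

Going by the values given here, the single measured step, an at least 2.3-fold higher number from compound 2 to compound 3 (0.37 log units; beyond the scatter), exchanges phenoxy for 2-phenoxyethyl and leaves the hydroxy question untouched. Among the compounds with values here, compound 1 and compound 2 differ in more than one place, so no step is computed between them; their two values simply show that the loss of both the hydroxy and the double-bonded chain carbons goes with a much higher number.

Compound 4 `O=C(O)c1csc([C@H]2CC[C@@H]3[C@@H](/C=C/CCOc4ccccc4)[C@H](O)C[C@@H]3O2)n1` is compound 1 with hydrogen in place of hydroxy on a saturated chain carbon bound to a double-bonded chain carbon and a saturated chain carbon. Compound 4 keeps the double-bonded chain carbon that compound 2 lacks, so the change is expected to cost less than the whole gap from compound 1 to compound 2, yet still clearly beyond the scatter. The expected step is a 290-fold higher number from compound 1 to compound 4 (2.46 log units; beyond the scatter). Compound 4 is estimated at 400 nM, within 60 nM to 3000 nM.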

Compound 4, half-maximal effective concentration: 160 nM
For compound 4 the middle estimate is 2.5-fold (0.40 log units) above the measured one; the measured number falls inside the stated range.
By their numbers in this assay, from the lowest: compound 1; then compound 4; then compound 2. At a limit, above all of these: compound 3.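

In this assay the hydroxy on the saturated chain carbon bound to a double-bonded chain carbon and a saturated chain carbon now has a step of its own: the exchange for hydrogen gives a 110-fold higher number from compound 1 to compound 4 (2.06 log units; beyond the scatter) and is a large change by itself. Compound 1 and compound 2 differ in more than one place, so they could not separate the hydroxy from the double-bonded chain carbons; here everything else in compound 1 stays in place, and the 1-hydroxy-2-phenoxyethyl to 2-phenoxyethyl change alone accounts for the step. The hydroxy is thus a major contributor in this series, although the number without it remains far from the end of the range, since compound 4 gives 160 nM while compound 2, which also lacks the hydroxy and has a saturated chain, gives 4200 nM.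

Still open, from the compounds shown here alone, is whether a methoxy, a fluorine or an amine on this chain carbon would keep a number close to that of compound 1, or whether only the hydroxy does so. Nothing measured on these compounds gives a reason for the size of the step.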